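A few compounds are considered here, and "the series" means these few. Any claim that something is new, unique, unknown or untested is made for them only; others in the source may bear on it.

Measured so far:
- compound 1 `Cc1ccc(C2CCN(CC(=O)Nc3cccc(C)c3)CC2)nc1`: "not active" (no number reported)
- compound 2 `Cc1cccc(NC(=O)CN2CCC(c3ccccc3)CC2)c1`: 242 nM

For the measured compounds named here, in an assay on cells for agonist activity at D(4) dopamine receptor (Homo sapiens), read by luminescence and beta-arrestin recruitment, with a stated time of 90 min (a higher number here means that more compound is needed for the effect, a lower number that less compound is needed), compound 2 gives 242 nM, the only numerical value; compound 1 is recorded as "not active" (no number reported) without a number, so compound 2 stands alone as the single reference point and no ordering between the two can be drawn.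

Compound 3 `Cc1cccc(NC(=O)CN2CCC(c3ccc(Cl)cc3)CC2)c1` differs from compound 2 by chloro in place of hydrogen on an aromatic carbon of the phenyl attached to the saturated ring. Going by the values given here, no pair of measured compounds shows this change, so the size of the step rests on no number here. A shift of modest size is expected, more likely toward less compound needed than toward more, though a result within the scatter of compound 2 would not surprise.

Compound 3 is estimated at 150 nM, between 40 nM and 600 nM, which means an expected step of a 1.6-fold lower number from compound 2 to compound 3 (0.21 log units; within the scatter).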

Compound 3, half-maximal effective concentration: "not active" (no number reported)
The entry for compound 3 holds no number; there is nothing to compare the estimate with.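

For the compounds shown here, compound 3 is recorded as "not active" (no number reported), so no step from compound 2 to compound 3 can be read. No available evidence bears on this result. The compounds shown leave open how substituents on the phenyl ring relate to the activity of compound 2 at 242 nM.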